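Swapping a Bulky Ring-Bearing Group for a Small Amide

The compounds below may be only part of what the source reports. "The series", "measured", "known", "first", "only" and "open" are said of these compounds alone.

Measured compounds:
- Compound 1 `COc1ccc(-c2nc(/N=C(\N)NC3CCCCC3)sc2-c2ccc(OC)cc2)cc1`: in a functional assay (aorta) with Rattus norvegicus as the target (a higher number here means that more compound is needed for the effect, a lower number that less compound is needed), compound 1 gives > 100 uM, which is a limit of the assay and not a number.
- Compound 2 `COc1ccc(-c2nc(CNC(=O)CSC)sc2-c2ccc(OC)cc2)cc1`: in this assay compound 2 gives 6 uM.
- Compound 3 `COc1ccc(-c2nc(CNC(=O)NC(C)C)sc2-c2ccc(OC)cc2)cc1`: in this assay compound 3 gives 5.7 uM.

Within the data shown here, compound 1 stands at the assay limit, the only one of the three values to do so (the limit of > 100 uM in this assay, at which 1 of the 3 values shown sits). Compound 4 `COc1ccc(-c2nc(C(=O)N(C)C)sc2-c2ccc(OC)cc2)cc1` has not yet been measured. It differs from compound 1 in one place: a group of 5 heavy atoms (3 carbon, 1 nitrogen, 1 oxygen; no ring) in place of a group of 10 heavy atoms (7 carbon, 3 nitrogen; one six-membered non-aromatic ring of carbon only), on an aromatic carbon. Among the measured compounds shown here, two measured steps bear on this change, since both also replace the same group on the same aromatic carbon with a small chain carrying a carbonyl: an at least 16-fold lower number from compound 1 to compound 2 (1.22 log units; beyond the scatter) and an at least 17-fold lower number from compound 1 to compound 3 (1.24 log units; beyond the scatter). Between the two small chains the outcome was nearly the same (a 1.1-fold lower number from compound 2 to compound 3 (0.02 log units; within the scatter)). The dimethylcarbamoyl group of compound 4 is smaller still and carries no hydrogen-bond donor, a feature neither compound 2 nor compound 3 tests, so the uncertainty is wider than for the measured steps. A lower number is nonetheless expected for compound 4, a step of an at least 6.6-fold lower number from compound 1 to compound 4 (0.82 log units; beyond the scatter). Compound 4 is estimated at 15 uM, between 3 uM and 80 uM.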

Compound 4, concentration for half-maximal effect: 3 uM
Compound 4: the middle estimate sits 5.0-fold (0.70 log units) above what was measured; the range from low to high includes it.
By their numbers in this assay, from the lowest: compounds 4, 3 and 2 (each within the scatter of the next). At a limit, above all of these: compound 1.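

Compound 4 shows that this aromatic carbon of the shared core can carry a much shorter group, dimethylcarbamoyl with its 5 heavy atoms, and still give a clear response, with an at least 33-fold lower number from compound 1 to compound 4 (1.52 log units; beyond the scatter). It also shows that the amide hydrogen present in compound 2 and compound 3 is not required in this group: dimethylcarbamoyl has 0 hydrogen-bond donors, yet a 1.9-fold lower number from compound 3 to compound 4 (0.28 log units; within the scatter) and a 2.0-fold lower number from compound 2 to compound 4 (0.30 log units; within the scatter), so these three compounds cannot be told apart in this assay. The figure for compound 1 remains a limit and not a number, so the first of these steps has no known upper end: the limit of > 100 uM in this assay, at which 1 of the 4 values shown sits.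

The compounds shown do not separate the roles of the two parts of the group that leaves, the six-membered carbon ring and the nitrogen-rich chain that carries it, since both go in a single change. As far as these compounds go, it also remains open how far this position can be simplified, as a primary amide, a carboxylic acid, a plain aminomethyl group or a longer chain on the same carbon would each test a different limit of what the response allows.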